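The compounds below may be only part of what the source reports. "The series", "measured", "known", "first", "only" and "open" are said of these compounds alone.

Compound 1 `O=C1/C(=C/c2ccncc2)CN(S(=O)(=O)c2ccc([N+](=O)[O-])cc2)C/C1=C\c1ccccc1F` carries a nitro group on its sulfonyl-bearing ring, and in a functional assay on HepG2 cells (Homo sapiens) for cytotoxicity, read by MTT assay, with a stated time of 24 h (on this read-out higher numbers stand for weaker inhibition and lower numbers for stronger inhibition), compound 1 gives 11300 nM. Compound 2 `O=C1/C(=C/c2ccncc2)CN(S(=O)(=O)c2ccc(C(F)(F)F)cc2)C/C1=C\c1ccccc1F` shares the core of compound 1 and differs from it only by trifluoromethyl in place of nitro on an aromatic carbon; in this assay compound 2 gives 4030 nM. That single change produced a 2.8-fold lower number from compound 1 to compound 2 (0.45 log units; beyond the scatter).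

Compound 3 `O=C1/C(=C/c2cccnc2)CN(S(=O)(=O)c2ccc([N+](=O)[O-])cc2)C/C1=C\c1ccccc1C(F)(F)F` is built on a different core, and the difference between the core of compound 1 and that of compound 3 is not broken down here. In this assay compound 3 gives 9370 nM, which sits close to the number for compound 1 and apart from the number for compound 2.

Compound 4 `O=C1/C(=C/c2cccnc2)CN(S(=O)(=O)c2ccc(C(F)(F)F)cc2)C/C1=C\c1ccccc1C(F)(F)F` stands to compound 3 as compound 2 stands to compound 1: the change is trifluoromethyl in place of nitro on an aromatic carbon, the same change at the same place, on an aromatic carbon of a six-membered aromatic ring of carbon only, para to a large group. Among the four compounds this change occurs twice in all, once measured and once not. Because the measured instance a 2.8-fold lower number from compound 1 to compound 2 (0.45 log units; beyond the scatter) lowered the number by a modest step, compound 4 is expected to show a step of a 2.8-fold lower number from compound 3 to compound 4 (0.44 log units; beyond the scatter) of like size. The expectation rests on that single measured pair and on no other, so its spread is wide. Compound 4 is therefore estimated at 3400 nM, with a range from 1500 nM to 7500 nM.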

Compound 4, half-maximal inhibitory concentration: 1710 nM
Compound 4: middle estimate off by 2.0-fold (0.30 log units), on the high side; the measured number falls inside the stated range.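

Put in place of nitro on the core of compound 3, trifluoromethyl gave a 5.5-fold lower number from compound 3 to compound 4 (0.74 log units; beyond the scatter) in this assay, so the change lowered the number on both cores shown. Within the data shown here, the two steps differ in their printed size, but that gap does not separate them, and they can be read as one step of like size on both cores: the same change on two cores in this assay, a 2.8-fold lower number (0.45 log units; beyond the scatter) from compound 1 to compound 2 and a 5.5-fold lower number (0.74 log units; beyond the scatter) from compound 3 to compound 4, 2.0-fold (0.29 log units) apart, within the scatter of two such steps This supports carrying the change between these two cores in this assay, but it rests on only two pairs of compounds, so it does not show that the larger step on the core of compound 3 is a real feature of that core, why the number falls, or that the change would act the same way on any other core.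

The compounds shown compare only nitro and trifluoromethyl at this place, so it remains open how an amine, a carboxylic acid or a nitrile there would compare on either core. It also remains open which parts of the difference between the two cores, if any, bear on the size of the step, since no pair shown isolates them.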